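From a methylphenyl to a difluorophenyl on a shared core

The source may report more compounds than this note shows. Statements on the series, on what has been measured and on what is new or still open speak of the compounds shown alone.

Of the compounds shown here, two built on the same core have been tested in a functional assay on MKN-45 cells (Homo sapiens) for cytotoxicity, read by MTT assay, with a stated time of 72 h; on this read-out higher numbers stand for weaker inhibition and lower numbers for stronger inhibition. Compound 1 `COc1ccc(-c2ccnc(C(=O)Nc3ccc(Oc4ccnc5cc(OCCCN6CCN(C)CC6)c(OC)cc45)c(F)c3)c2)c(OC)c1` gives 330 nM in this assay. Compound 2 `COc1cc2c(Oc3ccc(NC(=O)c4nccc(-c5ccc(C)cc5)n4)cc3F)ccnc2cc1OCCCN1CCCCC1` gives 580 nM in this assay. Among the compounds with values here, of the two numbers, the one for compound 2 is the higher, but its gap to compound 1 falls within the scatter of repeated measurements, so the two compounds cannot be ranked against each other on this evidence.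

Compound 3 `COc1cc2c(Oc3ccc(NC(=O)c4nccc(-c5ccc(F)cc5F)n4)cc3F)ccnc2cc1OCCCN1CCCCC1` keeps everything of compound 2 except one group: 2,4-difluorophenyl in place of 4-methylphenyl on an aromatic carbon. Within the data shown here, no measured pair in this small set shows what such a swap does, so no direction can be read from the data, and the expectation must rest on the step being modest. Among the measured compounds shown here, with only two measured values and no comparable change among them, the step from compound 2 to compound 3 is expected to stay within the scatter, as a 1.2-fold lower number from compound 2 to compound 3 (0.06 log units; within the scatter). Compound 3 is therefore expected to give 500 nM in this assay, with a plausible range from 200 nM to 1500 nM.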

Compound 3, half-maximal inhibitory concentration: 1120 nM
For compound 3 the middle estimate is 2.2-fold (0.35 log units) below the measured one, and the stated range covers the measured number.
By their numbers in this assay, from the lowest: compounds 1, 2 and 3 (each within the scatter of the next, the first and the last beyond it).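

In this assay, within the data shown here, the swap of 4-methylphenyl for 2,4-difluorophenyl gives a 1.9-fold higher number from compound 2 to compound 3 (0.29 log units; within the scatter) and is the only change in this set that can be read in one place. It shows that, at this aromatic carbon next to the ring nitrogen, one carbon-only aromatic ring can replace another without a step that can be told apart from repeat-measurement noise. A real weakening cannot be claimed from this pair, and neither can the idea that the two groups are truly equal, since a single step says little about a position; nothing available bears on why the number falls where it does.

The swap removes the methyl group and adds two fluorines at once, so the compounds shown leave open what each of those changes does alone, and whether a phenyl ring carrying a single fluorine would behave the same way. They also leave open whether a group of a different kind at this position, such as a morpholine ring, an aminomethyl group or a carboxylic acid, would move the number beyond the scatter.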